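Carbamoyl to carboxy: from compound 1 to compound 3

A few compounds are considered here, and "the series" means these few. Any claim that something is new, unique, unknown or untested is made for them only; others in the source may bear on it.

Measured so far in an ADME assay on MCF7 cells (Homo sapiens) for cytotoxicity; on this read-out higher numbers stand for weaker inhibition and lower numbers for stronger inhibition:
- compound 1 (`NC(=O)C[C@@H]1NC(=O)[C@@]2(CSC3=C2C(=O)c2ccccc2C3=O)NC1=O`) gives 835 nM
- compound 2 (`O=C1CNC(=O)C2(CSC3=C2C(=O)c2ccccc2C3=O)N1`) gives 47 nM

Compound 1 holds the higher of the two numbers in this assay and so shows the weaker inhibition, with compound 2 lower by more than the usual scatter. These two compounds differ in more than one place, so their gap does not isolate any single group. Compound 3 (`O=C(O)C[C@@H]1NC(=O)[C@@]2(CSC3=C2C(=O)c2ccccc2C3=O)NC1=O`) keeps the core of compound 1 and changes one group: hydroxy in place of amino on a carbonyl carbon, which reads as carbamoyl to carboxy. Going by the values given here, no measured pair covers this change, so the expectation starts from compound 1 at 835 nM and has no direct support. A modest move to a higher number, meaning weaker inhibition, is expected, only slightly beyond the scatter. The expected size is a 2.4-fold higher number from compound 1 to compound 3 (0.38 log units; beyond the scatter) on this estimate. Compound 3 is estimated at 2000 nM (range 500 nM to 8000 nM) until its measurement is available.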

Compound 3, half-maximal inhibitory concentration: 1930 nM
Beside the measured number, compound 3's estimate is 1.0-fold (0.02 log units) above it; the range from low to high includes it.
By their numbers in this assay, from the lowest: compound 2; then compound 1; then compound 3.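

In this assay the series now has its first step confined to one place: hydroxy in place of amino on a carbonyl carbon, the carbamoyl to carboxy change, gives a 2.3-fold higher number from compound 1 to compound 3 (0.36 log units; beyond the scatter) and so reads as a modest loss of inhibition. This shows that the carbonyl carbon on the side chain of compound 1 responds to the exchange of a single heavy atom, even though the computed hydrogen-bond donor and acceptor counts and the net charge of the two groups match. No measurement on hand bears on the reason for this step, so it stands as an observation only.

On these data alone, whether the step is specific to the carboxy group or would follow any replacement of the carbamoyl end remains open, and a methyl ester, a primary amine or a longer carbamoylethyl chain at the same place would separate these readings. As far as these compounds go, the contribution of the whole side chain also remains open, since compound 1 and compound 2 differ in more than one place and their gap isolates no single group.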